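The compounds below may be only part of what the source reports. "The series", "measured", "known", "first", "only" and "open" are said of these compounds alone.

The measured compounds are:

Compound 1, `CC(O)n1cnc2c(N)nc(I)nc21`, which in a functional assay on FM3A cells (Homo sapiens) for inhibition, with FM3A (Mus musculus) as the target (on this read-out higher numbers stand for weaker inhibition and lower numbers for stronger inhibition), gives 452000 nM
Compound 2, `CC(=O)OC(C)n1cnc2c(N)nc(I)nc21`, which in this assay gives 462000 nM
Compound 3, `CC(=O)OC(C)n1cnc2c(S)nc(F)nc21`, which in this assay gives 368000 nM

All three numbers lie within the scatter of one another, so no order among compounds 1, 2 and 3 can be read from them. Compound 2 and compound 1 differ in one place, (hydrogen in place of acetyl on an oxygen on a saturated carbon), and this change gave a 1.0-fold lower number from compound 2 to compound 1 (0.01 log units; within the scatter). How the core of compound 3 differs from the core of compound 2 is not broken down here.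

Compound 4, `CC(O)n1cnc2c(S)nc(F)nc21`, has not yet been measured. It differs from compound 3 by hydrogen in place of acetyl on an oxygen on a saturated carbon. Among the compounds with values here, this is the same change as the one from compound 2 to compound 1, at the same kind of place. Compound 4 is therefore expected to sit close to compound 3, with an estimated step of a 1.0-fold higher number from compound 3 to compound 4 (0.00 log units; within the scatter), because a 1.0-fold lower number from compound 2 to compound 1 (0.01 log units; within the scatter) showed this change leaving the number essentially unmoved. Compound 4 is expected to give about 370000 nM, in a range from 190000 nM to 720000 nM.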

Compound 4, half-maximal inhibitory concentration: > 500000 nM
Compound 4 gave a limit, no number; the forecaster's own chance of this, stated with the estimate: 15%; middle value at least 1.3-fold (0.13 log units) from the limit.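

In this assay compound 4 gave > 500000 nM, which is a limit of the assay and not a number. Acetoxy to hydroxy on the core of compound 3 therefore amounts to an at least 1.3-fold higher number from compound 3 to compound 4 (0.13 log units; that floor lies within the scatter), and the comparison with the same change on the core of compound 1 goes only this far: the same change on two cores in this assay, a 1.0-fold lower number (0.01 log units; within the scatter) from compound 2 to compound 1 and an at least 1.3-fold higher number (0.13 log units; that floor lies within the scatter) from compound 3 to compound 4; the limit leaves it open whether they differ. On these data alone, the two pairs thus give no sign that the change behaves differently on the two cores, but they do not show that it carries over unchanged, as the actual reading of compound 4 remains unknown.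

The compounds shown leave open how an amine or a longer acyl chain such as butyryl would read at this oxygen-bearing carbon on either core. They also leave open how acetoxy to hydroxy would read on any core other than these two, so nothing can yet be said about the series as a whole.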